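From Bare Ring to Chloro: Expecting a Small Step

The compounds below may be only part of what the source reports. "The series", "measured", "known", "first", "only" and "open" are said of these compounds alone.

Compound 3 `O=C(Nc1nn[nH]n1)c1ccccn1` sits at the bottom of the three numbers gathered so far. In a functional assay on the whole organism for inhibition, with Rattus norvegicus as the target, at a dose of 1 mg/kg by the oral route (on this read-out lower numbers stand for a weaker effect and higher numbers for a stronger effect at the one dose given), compound 3 gives 0%. Compound 1 `O=C(Nc1nn[nH]n1)c1cc(Br)ccn1`, which carries a bromo group on the shared core, gives 9% in this assay, and compound 2 `Cc1cc(Cl)cc(C(=O)Nc2nn[nH]n2)n1`, which carries both a chloro group and a methyl group, gives 66%. Compound 4 `O=C(Nc1nn[nH]n1)c1cc(Cl)ccn1` has not yet been measured. It differs from compound 3 in one place: chloro in place of hydrogen on an aromatic carbon. For the measured compounds named here, the only measured step that bears on this change is a number 9 percentage points lower from compound 1 to compound 3 (within the scatter), a halogen on the shared core giving way to hydrogen, and that step stayed within the scatter. Compound 2 offers no clean comparison: its chloro group arrives together with a methyl group, and the two cannot be separated. Compound 4 is therefore expected to show a step of a number 10 percentage points higher from compound 3 to compound 4 (within the scatter), small and at most slightly upward. Compound 4 is estimated at 10%, within a range from 0% to 30%.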

Compound 4, a percentage reported as inhibition, in the whole organism at one dose (the size of the read-out at that dose, not a potency): 38%
Compound 4: middle estimate off by 28 percentage points, on the low side; measured number above the stated range.
By their numbers in this assay, from the lowest: compounds 3 and 1 (each within the scatter of the next); then compound 4; then compound 2.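

In this assay, the place opposite the ring nitrogen proves sensitive to which halogen sits there: chloro on the bare core gives a number 38 percentage points higher from compound 3 to compound 4 (beyond the scatter) and, measured against bromo, a number 29 percentage points higher from compound 1 to compound 4 (beyond the scatter), so the two halogens cannot be treated as interchangeable here. The methyl group of compound 2 can now be read apart from its chloro, with a number 28 percentage points lower from compound 2 to compound 4 (beyond the scatter) when hydrogen replaces methyl, so methyl adds to the effect that chloro already gives. No measurement here gives a reason for either the gap between chloro and bromo or the gain from methyl.

Going by these compounds, whether methyl would raise the number on the bare core without chloro remains open. So does whether fluoro, a methoxy group or an amine at the chloro position would behave like chloro or like bromo.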